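Thiophene to pyridine swap on the trimethoxy chalcone

The source may hold more compounds than are shown below. What is called first, only, known or untested is meant among the compounds shown, and "the series" means these compounds.

Measured so far in a functional assay on HCT-116 cells (Homo sapiens) for inhibition, read by sulforhodamine B assay, with a stated time of 72 h; a higher number here means a weaker inhibitor, a lower number a stronger inhibitor:
compound 1 `COc1cc(OC)c(C(=O)/C=C/c2cn(-c3ccccc3)nc2-c2ccsc2)c(OC)c1`, 5200 nM
compound 2 `COc1ccc(C(=O)/C=C/c2cn(-c3ccccc3)nc2-c2ccsc2)c(OC)c1`, 2200 nM
compound 3 `O=C(/C=C/c1cn(-c2ccccc2)nc1-c1cccnc1)c1ccccc1`, 2000 nM

Compound 1 carries the highest number of the three. Within the data shown here, the one single-point step in the set, a 2.4-fold lower number from compound 1 to compound 2 (0.37 log units; beyond the scatter), takes the trimethoxy pattern down by one methoxy. Compound 3, which pairs the pyridin-3-yl with an unsubstituted benzoyl, gives 2000 nM, but it differs from compound 1 in more than one place, so only the two values themselves can be compared.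

Compound 4 `COc1cc(OC)c(C(=O)/C=C/c2cn(-c3ccccc3)nc2-c2cccnc2)c(OC)c1` makes the change (pyridin-3-yl in place of thiophen-3-yl on an aromatic carbon), while keeping the trimethoxy benzoyl of compound 1. Among the measured compounds shown here, no measured step isolates this exchange; the methoxy step from compound 1 to compound 2 does not touch the five-membered ring substituent. For the measured compounds named here, with no step of the same kind to lean on, the expected step of a 1.3-fold lower number from compound 1 to compound 4 (0.11 log units; within the scatter) is set close to no change beyond the scatter. For compound 4 the estimate in this assay is therefore 4000 nM, with a range from 1500 nM to 12000 nM.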

Compound 4, half-maximal inhibitory concentration: 300 nM
Compound 4: the middle estimate sits 13-fold (1.12 log units) above what was measured; measured number outside the range, below it.
By their numbers in this assay, from the lowest: compound 4; then compounds 3 and 2 (each within the scatter of the next); then compound 1.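

In this assay the aromatic group next to the ring nitrogen of the five-membered aromatic ring proves highly sensitive to change: with the trimethoxy benzoyl kept, pyridin-3-yl in place of thiophen-3-yl gives a 17-fold lower number from compound 1 to compound 4 (1.24 log units; beyond the scatter) and thus a large gain. That step far outweighs the modest one on the benzoyl side, a 2.4-fold lower number from compound 1 to compound 2 (0.37 log units; beyond the scatter), so among the changes that can be read singly, this position has the greater effect on the number. No measurement at hand accounts for the gain.

Among these compounds, whether the gain depends on the trimethoxy benzoyl remains open, since the only other pyridin-3-yl compound differs from compound 4 in more than one place. A plain phenyl or a pyridin-4-yl at this position would test whether the presence and placement of the ring nitrogen govern the effect.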